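Adding a Chloro Group to a Benzyl Piperidine

A few compounds are considered here, and "the series" means these few. Any claim that something is new, unique, unknown or untested is made for them only; others in the source may bear on it.

Compound 3 `COc1ccc2nccc(C3CN(C4CCN(Cc5ccccc5)CC4)C(=O)O3)c2c1` gives 12600 nM in an in vitro functional assay on RBL cells for antagonist activity at C-C chemokine receptor type 8 (Homo sapiens), read by FLIPR and calcium flux; on this read-out higher numbers stand for weaker inhibition and lower numbers for stronger inhibition. Compound 2 `COc1ccc2nccc(C3CN(C4CCN(CC5CCCCC5)CC4)C(=O)O3)c2c1` gives 7940 nM in this assay. Compound 1 `COc1ccc2nccc(C3CN(C4CCN(C)CC4)C(=O)O3)c2c1` shows only a limit, < 50200 nM, not a number. Of the two numbers, compound 3 has the higher, yet the step of a 1.6-fold higher number from compound 2 to compound 3 (0.20 log units; within the scatter) lies within the scatter, so the two compounds are not told apart. Compound 4 `COc1ccc2nccc(C3CN(C4CCN(Cc5cccc(Cl)c5)CC4)C(=O)O3)c2c1` differs from compound 3 by chloro in place of hydrogen on an aromatic carbon. Within the data shown here, no measured step touches a chloro group, and the steps a step that the limit leaves unreadable from compound 1 to compound 2 and a step that the limit leaves unreadable from compound 1 to compound 3 are unreadable, compound 1 sitting at the limit of < 50200 nM in this assay, at which 1 of the 3 values shown sits. Among the measured compounds shown here, the only readable step is small, so no change beyond the scatter is expected. Compound 4 is estimated at 10000 nM, between 3500 nM and 30000 nM. The expected step is a 1.3-fold lower number from compound 3 to compound 4 (0.10 log units; within the scatter).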

Compound 4, half-maximal inhibitory concentration: 6310 nM
The estimate for compound 4 lay 1.6-fold (0.20 log units) above the measured number, and the stated range covers the measured number.
By their numbers in this assay, from the lowest: compounds 4, 2 and 3 (each within the scatter of the next).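

In this assay, chloro in place of hydrogen on this aromatic ring gives a 2.0-fold lower number from compound 3 to compound 4 (0.30 log units; within the scatter), so this first change on the ring does not separate the two compounds. The wider change, 3-chlorophenyl in place of cyclohexyl, gives a 1.3-fold lower number from compound 2 to compound 4 (0.10 log units; within the scatter), which again separates nothing. The step from compound 1 cannot be read, as compound 1 has a limit and not a number: the limit of < 50200 nM in this assay, at which 1 of the 4 values shown sits.

From the compounds shown here alone, whether a different group on this ring, such as a nitrile or an amine, could shift the number beyond the scatter remains open.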